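Indolyl Replaces Chloro on a Core That Shows Only Limits

A few compounds are considered here, and "the series" means these few. Any claim that something is new, unique, unknown or untested is made for them only; others in the source may bear on it.

Compound 1 `Cc1cc(Cl)nnc1N1CCN(c2ncccn2)CC1` is the starting point. In a functional assay on BV-2 cells (Mus musculus) for inhibition, read by ELISA, with a stated time of 16 h (on this read-out higher numbers stand for weaker inhibition and lower numbers for stronger inhibition), compound 1 gives > 100000 nM, which is a limit of the assay and not a number. Compound 2 `Cc1cc(C)c(N2CCN(c3ncccn3)CC2)nn1` gives > 100000 nM in this assay, again only a limit. Compound 3 `Cc1cc(-c2cncnc2)nnc1N1CCN(c2ncccn2)CC1` gives > 100000 nM in this assay, also a limit. The three steps among them are therefore a step that the two limits leave unreadable from compound 1 to compound 2, a step that the two limits leave unreadable from compound 1 to compound 3 and a step that the two limits leave unreadable from compound 2 to compound 3, and every value sits at the limit of > 100000 nM in this assay, at which 3 of the 3 values shown sit. Compound 4 `Cc1cc(-c2ccc3[nH]ccc3c2)nnc1N1CCN(c2ncccn2)CC1` differs from compound 1 in one place: 1H-indol-5-yl in place of chloro on an aromatic carbon. Going by the values given here, of the measured steps, only the one from compound 1 to compound 3 brings in an aryl group of comparable kind, and its size is unreadable; the other two concern a methyl and bear little on this change. With every value a limit, no direction can be expected with confidence. Compound 4 is expected at 50000 nM, with a range from 5000 nM to 200000 nM. The expected step of an at least 2.0-fold lower number from compound 1 to compound 4 (0.30 log units; that floor lies within the scatter) is thus modest at most, and a further limit remains the likeliest outcome.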

Compound 4, half-maximal inhibitory concentration: 85100 nM
For compound 4 the middle estimate is 1.7-fold (0.23 log units) below the measured one, and the stated range covers the measured number.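

In this assay compound 4 alone gives a number rather than a limit, which shows that the place held by chloro in compound 1 can carry 1H-indol-5-yl with a readable result. The change comes out as an at least 1.1-fold lower number from compound 1 to compound 4 (0.07 log units; that floor lies within the scatter), and the other two steps, an at least 1.1-fold lower number from compound 3 to compound 4 (0.07 log units; that floor lies within the scatter) and an at least 1.1-fold lower number from compound 2 to compound 4 (0.07 log units; that floor lies within the scatter), are likewise only floors, so none is shown to go beyond the scatter. The steps among compounds 1, 2 and 3 still cannot be read: the limit of > 100000 nM in this assay, at which 3 of the 4 values shown sit.

As far as these compounds go, whether the readable value depends on the whole 1H-indol-5-yl group or on its hydrogen-bond donor stays open, and a plain phenyl group would bear on that. From the compounds shown here alone, how far the value can move at this place also stays open, for instance with an amine or a carboxylic acid there.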